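Aryl sulfonate amides: estimating the urea analogue, compound 4

The compounds below may be only part of what the source reports. "The series", "measured", "known", "first", "only" and "open" are said of these compounds alone.

Values in a functional assay on M21 cells (Homo sapiens) for antiproliferative activity, read by sulforhodamine B assay, with a stated time of 48 h (a lower number here means a stronger inhibitor, a higher number a weaker inhibitor), for the measured set:
- compound 1 `CCC(=O)Nc1ccc(S(=O)(=O)Oc2ccccc2I)cc1`: 11000 nM
- compound 2 `CCCCCC(=O)Nc1ccc(S(=O)(=O)Oc2ccccc2I)cc1`: 11000 nM
- compound 3 `O=C(CCCCl)Nc1ccc(S(=O)(=O)Oc2ccccc2I)cc1`: 7200 nM

Compound 3 gives the lowest of the three numbers in this assay, but its steps to the other two are small: a 1.5-fold lower number from compound 1 to compound 3 (0.18 log units; within the scatter) and a 1.5-fold lower number from compound 2 to compound 3 (0.18 log units; within the scatter). The three compounds therefore sit together, and no order among them can be claimed.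

Compound 4 `CCCCCNC(=O)Nc1ccc(S(=O)(=O)Oc2ccccc2I)cc1` is the next member. Relative to compound 3 the change is pentylamino in place of 3-chloropropyl on a carbonyl carbon, which turns the amide of compound 3 into a urea. Among the measured compounds shown here, none of the measured steps covers this exchange. What they do show is that altering the acyl chain has so far moved this assay little: no change at the digits printed from compound 1 to compound 2 (within the scatter), a 1.5-fold lower number from compound 1 to compound 3 (0.18 log units; within the scatter) and a 1.5-fold lower number from compound 2 to compound 3 (0.18 log units; within the scatter) all lie within the scatter. As far as these compounds go, on that basis no shift beyond the scatter is expected for compound 4, with wider uncertainty because the amide-to-urea exchange is untested here. For compound 4 the expected value in this assay is 8000 nM, with a range from 3000 nM to 22000 nM, which means an expected step of a 1.1-fold higher number from compound 3 to compound 4 (0.05 log units; within the scatter).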

Compound 4, half-maximal inhibitory concentration: 5900 nM
Compound 4: the middle estimate sits 1.4-fold (0.13 log units) above what was measured; the range from low to high includes it.
By their numbers in this assay, from the lowest: compounds 4, 3, 1 and 2 (each within the scatter of the next).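

In this assay, the position on the carbonyl carbon, until now occupied only by carbon chains in amides, is shown to accept pentylamino as a urea, with a 1.2-fold lower number from compound 3 to compound 4 (0.09 log units; within the scatter), a 1.9-fold lower number from compound 2 to compound 4 (0.27 log units; within the scatter) and a 1.9-fold lower number from compound 1 to compound 4 (0.27 log units; within the scatter). The closest comparison is the second of these, where pentyl and pentylamino differ only in the nitrogen that adds a hydrogen-bond donor, and that exchange also stays within the scatter, so the amide-to-urea change joins the acyl chain changes as one that moves this read-out no further than repeat measurements would. No measurement is available that explains this flat response.

The four compounds share one core and carry only open chains on the carbonyl carbon, so they leave open whether any group at this position can move the number beyond the scatter, for example a much longer chain, a chain ending in an amine or a carboxylic acid, or a phenyl ring on the urea nitrogen. How the number responds to changes in the core itself also cannot be read from these compounds.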